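The source may report more compounds than this note shows. Statements on the series, on what has been measured and on what is new or still open speak of the compounds shown alone.

Compound 1 `CNCC(=O)Nc1cc(OC)ccc1C(=O)c1ccc(OC)c2c1OC(C)(C)C=C2` gives 620 nM in a functional assay on A2780 cells (Homo sapiens) for antiproliferative activity, read by MTT assay, with a stated time of 48 h; a higher number here means a weaker inhibitor, a lower number a stronger inhibitor
Compound 2 `COc1ccc(C(=O)c2cc(OC)c(OC)c(OC)c2)c(NC(=O)CN(C)C)c1` gives 580 nM in this assay
Compound 3 `C=C(c1ccc2c(c1)C=CC(C)(C)O2)c1ccc(OC)cc1NC(=O)CN` gives 140 nM in this assay

For the measured compounds named here, of these three numbers, the one for compound 3 is the lowest, and its gap to each of the other two lies beyond the usual scatter of repeated measurements. That makes compound 3 the strongest inhibitor of the three.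

Compound 4 `C=C(c1ccc2c(c1)C=CC(C)(C)O2)c1ccc(OC)cc1NC(=O)CNCC` departs from compound 3 in a single place. The change is ethyl in place of hydrogen on an amine nitrogen and amounts to ethyl in place of hydrogen on an amine nitrogen.

Going by the values given here, no two measured compounds differ in one place only, so the data give no direct measure of what such a change does. Compound 1 and compound 2 differ from compound 3 in more than this one place, so their higher numbers say little about it. With compound 3 at 140 nM as the only close starting point, a slight weakening is expected, small enough that it may not exceed the scatter. The estimated change is a 1.4-fold higher number from compound 3 to compound 4 (0.15 log units; within the scatter) in this assay and it is expected to stay within the scatter. With so little to go on, the range is kept wide. For compound 4 the expected value is 200 nM with an estimated range from 70 nM to 600 nM in this measurement.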

Compound 4, half-maximal inhibitory concentration: 1870 nM
The estimate for compound 4 lay 9.4-fold (0.97 log units) below the measured number, outside the stated range (above it).
By their numbers in this assay, from the lowest: compound 3; then compounds 2 and 1 (each within the scatter of the next); then compound 4.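

Ethyl in place of hydrogen on the amine nitrogen gives a 13-fold higher number from compound 3 to compound 4 (1.13 log units; beyond the scatter) in this assay, a large loss of activity from a group of only 2 heavy atoms. For the compounds shown here, this is the first direct reading of any single change, as none of the earlier compounds formed a pair differing in one place, and it marks this nitrogen, whose other neighbour is a saturated chain carbon, as a place where the shared core tolerates this addition poorly. No measurement at hand explains why the step is so large.

A single step cannot show whether the loss grows with the size of the group on this nitrogen, or whether a propyl chain, a cyclopropyl ring or a hydroxyethyl group would behave like ethyl on the core of compound 3. Compound 1 and compound 2 also carry substituted amines, but they differ from compound 3 in more than one place, so they cannot settle this.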